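A Methyl Added One Bond Out: Compound 2 to Compound 4

The compounds below may be only part of what the source reports. "The series", "measured", "known", "first", "only" and "open" are said of these compounds alone.

Compound 2 `Cn1cc(-c2ccccc2NCC2=NCCN2)cn1` gives 0% in a functional assay with Alpha-1B adrenergic receptor (Homo sapiens) as the target, read by calcium flux (on this read-out higher numbers stand for larger maximal responses and lower numbers for smaller maximal responses), level with compound 1 `Cc1n[nH]c(-c2ccccc2NCC2=NCCN2)n1` at 0%, the two together the lowest of three numbers. Compound 3 `Cn1ncnc1-c1ccccc1NCC1=NCCN1` stands far higher at 93%; the steps of a number 93 percentage points higher from compound 2 to compound 3 (beyond the scatter) and a number 93 percentage points higher from compound 1 to compound 3 (beyond the scatter) are both large, while no change at the digits printed from compound 1 to compound 2 (within the scatter) lies within the scatter. Compound 4 `CCn1cc(-c2ccccc2NCC2=NCCN2)cn1` differs from compound 2 only by methyl in place of hydrogen on a saturated chain carbon bound to an aromatic nitrogen. Among the compounds with values here, no measured step touches this spot: each of the three exchanges a whole ring on the aromatic carbon, and the large ones replace the ring rather than lengthen a chain. Compound 4 is therefore expected to stay near the low pair, with no change at the digits printed from compound 2 to compound 4 (within the scatter). For compound 4 the estimate is 0%, between 0% and 15%.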

Compound 4, largest response reached (reported as maximal response), in percent of the reference or control that the assay uses: 0%
Estimate against measurement, compound 4: no gap at the digits printed; the measured number falls inside the stated range.
By their numbers in this assay, from the lowest: compounds 1, 2 and 4 (each within the scatter of the next); then compound 3.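

In this assay, going from methyl to ethyl on the aromatic nitrogen gives no change at the digits printed from compound 2 to compound 4 (within the scatter). Within the data shown here, this is the first measured change at this spot, where the earlier steps each exchanged a whole ring, and one added methyl here leaves the response as low as before. No measurement at hand offers an explanation for this result.

As far as these compounds go, whether a propyl chain, or a chain ending in an amine or a carboxylic acid, would give a response at this spot stays open. So does whether an ethyl in place of the methyl on the ring of compound 3 would keep that compound's high response.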